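A few compounds are considered here, and "the series" means these few. Any claim that something is new, unique, unknown or untested is made for them only; others in the source may bear on it.

Three compounds of the shared core carry values in a functional assay on the whole organism with Rattus norvegicus as the target; on this read-out lower numbers stand for an effect already at smaller amounts and higher numbers for an effect only at larger amounts of compound. Compound 1 `CC(C)c1ccc2nc(N)sc2c1` reaches only a limit in this assay, > 10 mg/kg. Compound 2 `Nc1nc2ccc(C(F)(F)C(F)(F)F)cc2s1` gives 2.5 mg/kg in this assay. Compound 3 `CCCn1c(=N)sc2cc(OC(F)(F)F)ccc21` gives 4.5 mg/kg in this assay, the higher of the two numbers, though the gap to compound 2 lies within the scatter. Compound 4 `N=c1sc2cc(OC(F)(F)F)ccc2n1CCSc1ccccc1` has not been measured in this assay. It differs from compound 3 by phenylsulfanyl in place of methyl on a saturated chain carbon, two bonds along the chain from an aromatic nitrogen. For the measured compounds named here, no measured pair shows a change of this kind, so no step beyond the scatter is expected in either direction. Compound 4 is expected to give 4.5 mg/kg in this assay, between 1.5 mg/kg and 15 mg/kg, with the expected step of no change at the digits printed from compound 3 to compound 4 (within the scatter) staying within the scatter.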

Compound 4, dose for half-maximal effect: 4.5 mg/kg
Beside the measured number, compound 4's estimate shows no gap at the digits printed, and the stated range covers the measured number.
By their numbers in this assay, from the lowest: compounds 2, 3 and 4 (each within the scatter of the next). At a limit, above all of these: compound 1.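

Phenylsulfanyl in place of methyl on a saturated chain carbon, two bonds along the chain from an aromatic nitrogen, gives no change at the digits printed from compound 3 to compound 4 (within the scatter) in this assay, the first step read at this position. This one pair shows that the position accepts the larger group, with its six-membered aromatic ring, without a step beyond the scatter. The step is read between two numbers, and the only limit shown belongs to compound 1: the limit of > 10 mg/kg in this assay, at which 1 of the 4 values shown sits.

On these data alone, whether an amine, a carboxylic acid or phenoxy on this same chain carbon would read alike stays open.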